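Changing one group on a compound stuck at a limit

The source may report more compounds than this note shows. Statements on the series, on what has been measured and on what is new or still open speak of the compounds shown alone.

Compound 1 `CSc1nc(C)nc(SC)c1NC(=O)N(Cc1ccc(Oc2ccc(F)cc2)cc1)C1CCCCCC1`: 0.45 mg/kg
Compound 2 `COc1nc(C)cc(SC)c1NC(=O)N(Cc1ccc(Oc2ccc(F)cc2)cc1)C1CCCCCC1`: 1.4 mg/kg
Compound 3 `CSc1nc(C)cc(Cl)c1NC(=O)N(Cc1ccc(Oc2ccc(F)cc2)cc1)C1CCCCCC1`: > 1 mg/kg, a limit and not a number

All three compounds were tested in a functional assay on the whole organism with Rattus norvegicus as the target (on this read-out lower numbers stand for an effect already at smaller amounts and higher numbers for an effect only at larger amounts of compound), and they differ only in the group on the amide-type nitrogen. Compound 3 stands at a limit, > 1 mg/kg, so it has no exact number.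

Compound 4 `CSc1cc(C)nc(C)c1NC(=O)N(Cc1ccc(Oc2ccc(F)cc2)cc1)C1CCCCCC1` changes that same group once more: a group of 10 heavy atoms (8 carbon, 1 nitrogen, 1 sulfur; one six-membered aromatic ring with 1 hetero atom) in place of a group of 10 heavy atoms (7 carbon, 1 nitrogen, 1 sulfur, 1 chlorine; one six-membered aromatic ring with 1 hetero atom), on an amide-type nitrogen. The entering group has a carbon where the leaving group has a chlorine.

Two measured steps at this place bear on the change. The first is a 3.1-fold higher number from compound 1 to compound 2 (0.49 log units; beyond the scatter). The second is an at least 2.2-fold higher number from compound 1 to compound 3 (0.34 log units; beyond the scatter). Both are modest at the sizes shown, and both go towards higher numbers. The third step, a step that the limit leaves unreadable from compound 2 to compound 3, gives no usable size.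

Since changes at this place have so far been modest, compound 4 is expected to land near the other compounds, and compound 2 at 1.4 mg/kg is the nearest guide. The expected change is a step that the limit leaves unreadable from compound 3 to compound 4, which means no step beyond the scatter is expected in this assay. The estimate for compound 4 is 1.2 mg/kg, with an expected range from 0.5 mg/kg to 3 mg/kg.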

Compound 4, dose for half-maximal effect: < 1 mg/kg
Compound 4 was reported as a limit (the forecaster's own chance of this, stated with the estimate: 30%); middle value at least 1.2-fold (0.07 log units) from the limit.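

In this assay compound 4 stands at a limit and not a number, < 1 mg/kg. Compound 3 is also a limit, > 1 mg/kg. Putting a carbon where the chlorine stood gives a number no higher from compound 3 to compound 4 (the limit leaves the size open), and the two limits point in opposite directions from the same dose. Methyl in place of methoxy gives the first step at this position that points towards a lower number, an at least 1.4-fold lower number from compound 2 to compound 4 (0.14 log units; that floor lies within the scatter), but this floor alone does not establish a step beyond the scatter, and the true size could still be larger.

Going by these compounds, the sizes of the steps to compound 4 from compound 1 and from compound 3 cannot be read, so how compound 4 truly compares with either stays unknown, because the reported value is only a limit: the limit of < 1 mg/kg in this assay, at which 1 of the 4 values shown sits. It also remains open where an amine or a longer chain in place of that methyl would land in this assay.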